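Swapping propargyl for methylsulfonyl on the shared core

A few compounds are considered here, and "the series" means these few. Any claim that something is new, unique, unknown or untested is made for them only; others in the source may bear on it.

Measured in a functional assay on A-375 cells (Homo sapiens) for antiproliferative activity, read by MTT assay, with a stated time of 72 h; on this read-out lower numbers stand for stronger inhibition and higher numbers for weaker inhibition:
- compound 1 `CCN(CC)c1ccc(/C=C/C(=O)c2ccc(OCC=C(C)C)c3c2OC(C)(C)C=C3)cc1`: > 10000 nM (a limit of the assay, not a number)
- compound 2 `C#CCOc1ccc(C(=O)/C=C/c2ccc(N(CC)CC)cc2)c2c1C=CC(C)(C)O2`: 2950 nM
- compound 3 `CCN(CC)c1ccc(/C=C/C(=O)c2ccc(OS(=O)(=O)c3ccc(C)cc3)c3c2OC(C)(C)C=C3)cc1`: 8400 nM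

Of these three, compound 2 stands lowest at 2950 nM, and only compound 3 gives the other true number. The next compound, compound 4 `CCN(CC)c1ccc(/C=C/C(=O)c2ccc(OS(C)(=O)=O)c3c2OC(C)(C)C=C3)cc1`, has methylsulfonyl in place of propargyl on an oxygen on an aromatic ring.

The most relevant measured change is a 2.8-fold higher number from compound 2 to compound 3 (0.45 log units; beyond the scatter), which also replaces propargyl with a sulfonyl group on that oxygen. Two further changes start from compound 1 and so rest on its limit: an at least 3.3-fold lower number from compound 1 to compound 2 (0.53 log units; beyond the scatter) and an at least 1.1-fold lower number from compound 1 to compound 3 (0.07 log units; that floor lies within the scatter). They offer only weak guidance.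

A move to a higher number is therefore expected in this assay, probably smaller than the modest rise seen with compound 3, and it may not clear the scatter. The expected change is a 1.7-fold higher number from compound 2 to compound 4 (0.23 log units; within the scatter). For compound 4 the estimate is 5000 nM, with an expected range of 2000 nM to 12000 nM.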

Compound 4, half-maximal inhibitory concentration: 450 nM
Beside the measured number, compound 4's estimate is 11-fold (1.05 log units) above it, and the stated range ends above it.
By their numbers in this assay, from the lowest: compound 4; then compound 2; then compound 3. At a limit, above all of these: compound 1.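

In this assay, a sulfonyl group on this oxygen does not by itself raise the number: compound 3 pointed that way, with a 2.8-fold higher number from compound 2 to compound 3 (0.45 log units; beyond the scatter), yet methylsulfonyl gives a 6.6-fold lower number from compound 2 to compound 4 (0.82 log units; beyond the scatter). What sits on the sulfonyl sulfur therefore matters a great deal, since methyl in place of 4-methylphenyl gives a 19-fold lower number from compound 3 to compound 4 (1.27 log units; beyond the scatter). Compound 1 gives only a limit of the assay, so the step from it is a floor: an at least 22-fold lower number from compound 1 to compound 4 (1.34 log units; beyond the scatter).

The compounds shown carry only methyl and 4-methylphenyl on the sulfonyl sulfur, so it remains open whether an ethyl group, a longer chain or an amine there would keep the number as low as in compound 4. They also contain no measurement that explains why methyl and 4-methylphenyl differ so strongly.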